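The source may hold more compounds than are shown below. What is called first, only, known or untested is meant among the compounds shown, and "the series" means these compounds.

Compound 1: `COC(=O)N1CC2CNCC2C1` — "not determined" (no result reported)
Compound 2: `O=C(C1CC1)[C@H]1C[C@H]2CNC[C@H]2C1` — 18 nM

Compound 1, `COC(=O)N1CC2CNCC2C1`, was run in an assay on SHEP1 cells for agonist activity at Neuronal acetylcholine receptor; alpha4/beta2 (Homo sapiens), read by FLIPR and calcium flux (a higher number here means that more compound is needed for the effect, a lower number that less compound is needed), but no result was reported for it. Compound 2, `O=C(C1CC1)[C@H]1C[C@H]2CNC[C@H]2C1`, gives 18 nM in this assay. Within the data shown here, compound 2 therefore stands as the only compound with a number here; compound 1 carries no numerical result, so nothing can be said about how the two compare.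

Compound 3, `O=C(c1ccco1)[C@H]1C[C@H]2CNC[C@H]2C1`, is not yet measured. It differs from compound 2 in one place: furan-2-yl in place of cyclopropyl on a carbonyl carbon. Among the measured compounds shown here, no measured pair with this change is available, so the expectation for compound 3 rests on compound 2 alone. The author expects a small step towards more compound being needed, of a size that may not clear the usual scatter, estimated as a 1.7-fold higher number from compound 2 to compound 3 (0.22 log units; within the scatter). For compound 3 in this assay the author therefore expects a value near 30 nM, with a range from 8 nM to 120 nM, to be checked against the measurement once it is available.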

Compound 3, half-maximal effective concentration: 1600 nM
Compound 3: middle estimate off by 53-fold (1.73 log units), on the low side; measured number outside the range, above it.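

Placing furan-2-yl instead of cyclopropyl on the carbonyl carbon, whose other neighbour is a saturated ring carbon, gives an 89-fold higher number from compound 2 to compound 3 (1.95 log units; beyond the scatter) in this assay. Among these compounds, this is the first measured change at this position, and it shows that the read-out depends strongly on the group carried by the carbonyl, which compound 2 could not show on its own. The exchange alters several things at once, replacing a three-membered non-aromatic ring of carbon only with a five-membered aromatic ring with 1 hetero atom and bringing in 1 hydrogen-bond acceptor, and nothing available here bears on which of these features accounts for the step.

The compounds shown leave open whether the large step follows the ring size, the aromatic character or the ring oxygen, since these features change together between compound 2 and compound 3. Cyclopentyl on the same carbonyl would test ring size alone, while tetrahydrofuran-2-yl and thiophen-2-yl would each separate the ring oxygen from the other two features, and it remains open where such groups would fall relative to the two measured compounds.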